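Adding a fluoro group to the chlorophenyl amide of compound 1

This account rests on a few compounds, and the source may have more. Where it says the series, first, only, none or still open, it means among the compounds named here.

Compound 1 `O=C(CSc1nc(Nc2ccccc2)c2ccccc2n1)Nc1cccc(Cl)c1` was tested in a functional assay on MGC-803 cells (Homo sapiens) for inhibition, read by MTT assay, with a stated time of 72 h (on this read-out lower numbers stand for stronger inhibition and higher numbers for weaker inhibition), where compound 1 gives 14300 nM. Compound 3 `O=C(CSc1nc(Nc2ccccc2)c2ccccc2n1)Nc1ccc(Cl)cc1Cl` gives 12300 nM, so compound 1 holds the higher of the two numbers, though the pair lies within the scatter. Compound 2 `O=C(CSc1nc(Nc2ccccc2)c2ccccc2n1)Nc1ccc(F)cc1` reaches only the limit > 50000 nM. Compound 4 `O=C(CSc1nc(Nc2ccccc2)c2ccccc2n1)Nc1ccc(F)c(Cl)c1` differs from compound 1 by fluoro in place of hydrogen on an aromatic carbon. Within the data shown here, two measured steps bear on this. The step of a 1.2-fold lower number from compound 1 to compound 3 (0.07 log units; within the scatter) shows that adding a halogen to the ring of compound 1 changes little, while an at least 3.4-fold higher number from compound 1 to compound 2 (0.54 log units; beyond the scatter) and an at least 4.0-fold lower number from compound 2 to compound 3 (0.60 log units; beyond the scatter) show that 4-fluorophenyl alone is weaker. Compound 4 keeps the chloro group, so only a small, uncertain loss is expected, a 1.3-fold higher number from compound 1 to compound 4 (0.10 log units; within the scatter). Compound 4 is therefore estimated at 18000 nM, with a range from 8000 nM to 45000 nM.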

Compound 4, half-maximal inhibitory concentration: 20900 nM
Beside the measured number, compound 4's estimate is 1.2-fold (0.06 log units) below it; the range from low to high includes it.
By their numbers in this assay, from the lowest: compounds 3, 1 and 4 (each within the scatter of the next). At a limit, above all of these: compound 2.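

In this assay, placing fluoro on the ring carbon para to a large group and ortho to a chloro group gives a 1.5-fold higher number from compound 1 to compound 4 (0.16 log units; within the scatter), so this position tolerates fluoro when the chloro group is present, and changing the halogen pattern gives a 1.7-fold higher number from compound 3 to compound 4 (0.23 log units; within the scatter). Fluoro alone was the weak case, and adding the chloro group gives an at least 2.3-fold lower number from compound 2 to compound 4 (0.37 log units; beyond the scatter). That step starts from a limit and not a number: the limit of > 50000 nM in this assay, at which 1 of the 4 values shown sits.

Still open, on these data alone, is whether a methoxy group or an amine at this position would also be tolerated.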